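A few compounds are considered here, and "the series" means these few. Any claim that something is new, unique, unknown or untested is made for them only; others in the source may bear on it.

Measured compounds, inhibition in an assay on a protein complex for inhibition of CDK8/Cyclin C (Homo sapiens), with a stated time of 1 h, tested at 10 uM; a higher number here means more inhibition at the concentration tested (going by the name of the read-out), a lower number less inhibition:
compound 1 `CNC(=O)/C=C/c1ccncc1-c1ccc2ccccc2c1` gives 101%
compound 2 `NNC(=O)CCc1ccncc1-c1ccc2ccccc2c1` gives 102%
compound 3 `CCOC(=O)/C=C/c1ccncc1-c1ccc2ccccc2c1` gives 102%

Compound 3 stands level with compound 2 at the digits reported, the two together the highest of the three numbers, and its nearest neighbour is compound 2 with no change at the digits printed from compound 2 to compound 3 (within the scatter); compound 1 is the furthest, with a number 1 percentage points higher from compound 1 to compound 3 (within the scatter). Within the data shown here, all three steps lie within the scatter, so the series so far shows no separation at all.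

The next compound, compound 4 `CNC(=O)CCc1ccncc1-c1ccc2ccccc2c1`, differs from compound 3 as follows: 2-(methylcarbamoyl)ethyl in place of 2-(ethoxycarbonyl)ethenyl on an aromatic carbon. Among the measured compounds shown here, two measured steps bear on this. The step of a number 1 percentage points higher from compound 1 to compound 3 (within the scatter) shows that exchanging the group on the carbonyl carbon left the read-out unchanged, and the step of a number 1 percentage points higher from compound 1 to compound 2 (within the scatter) shows that saturating the two-carbon link while also altering the carbonyl substituent did likewise. Compound 4 combines a saturated link with the methylcarbamoyl end already present in compound 1. Against this background the expected step is a number 2 percentage points lower from compound 3 to compound 4 (within the scatter), none beyond the scatter. Compound 4 is therefore estimated at 100%, within 88% to 106%.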

Compound 4, a percentage reported as inhibition, at one concentration (the size of the read-out at that concentration, not a potency): 100%
Compound 4: the middle estimate sits on the measured number at the digits printed; the range from low to high includes it.
By their numbers in this assay, from the lowest: compounds 4, 1, 2 and 3 (each within the scatter of the next).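

In this assay, the link can now be read on its own: with the methylcarbamoyl end kept, 2-(methylcarbamoyl)ethyl in place of 2-(methylcarbamoyl)ethenyl gives a number 1 percentage points lower from compound 1 to compound 4 (within the scatter), whereas the earlier saturated compound also carried a different end group. On the saturated link, methyl in place of amino on the amide-type nitrogen gives a number 2 percentage points lower from compound 2 to compound 4 (within the scatter), and the change at this position opposite the ring nitrogen from the ester-bearing group of compound 3 gives a number 2 percentage points lower from compound 3 to compound 4 (within the scatter), so neither link nor end group separates these four compounds. No evidence is available that accounts for this result.

Going by these compounds, whether a carboxylic acid, a primary amine or a longer chain at this position would separate from these compounds remains open. On these data alone, the read-out at one concentration is not a potency, so any potency differences among the four also remain open.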